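One Stereocentre Left Undrawn

The source may hold more compounds than are shown below. What is called first, only, known or untested is meant among the compounds shown, and "the series" means these compounds.

In a functional assay on SW480 cells (Homo sapiens) for antiproliferative activity, read by MTT assay, with a stated time of 48 h (a higher number here means a weaker inhibitor, a lower number a stronger inhibitor), compound 1 `CCCC(CCO)n1cnc2c(Cl)ncnc21` gives > 50000 nM, which is a limit and not a number. Compound 2 `CCCCCCCC[C@@H](CCO)n1cnc2c(Cl)ncnc21` gives 2330 nM. Among the compounds with values here, compound 3 `CCCCCCCC[C@H](CCO)n1cnc2c(Cl)ncnc21` gives 320 nM, the lowest number measured so far. The measured step that bears most directly on compound 4 is the change of configuration alone, a 7.3-fold lower number from compound 2 to compound 3 (0.86 log units; beyond the scatter), a modest step. Compound 4 `CCCCCCCCC(CCO)n1cnc2c(Cl)ncnc21` changes only how that centre is drawn: the two compounds have the same atoms and bonds; at least one stereo element is drawn with a configuration in one of them and without one in the other: 1 of 1 stereo elements differ; a stereocentre at a saturated chain carbon is drawn R in compound 3 and without a configuration in compound 4. If compound 4 is a mix of both forms, its number is expected to fall between the values of compound 2 at 2330 nM and compound 3 at 320 nM, nearer the lower one. The expected step is a 1.9-fold higher number from compound 3 to compound 4 (0.27 log units; within the scatter), small beside the measured one. For compound 4 the estimate is 600 nM, with an expected range of 300 nM to 1500 nM.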

Compound 4, half-maximal inhibitory concentration: 1370 nM
Compound 4: middle estimate off by 2.3-fold (0.36 log units), on the low side; the range from low to high includes it.
By their numbers in this assay, from the lowest: compound 3; then compounds 4 and 2 (each within the scatter of the next). At a limit, above all of these: compound 1.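

In this assay there is a 4.3-fold higher number from compound 3 to compound 4 (0.63 log units; beyond the scatter) when the R centre is left undrawn, so the undrawn form does not match the R form. There is also a 1.7-fold lower number from compound 2 to compound 4 (0.23 log units; within the scatter) and so no separation from the S form. Pentyl in place of hydrogen on the chain carbon gives an at least 36-fold lower number from compound 1 to compound 4 (1.56 log units; beyond the scatter) with the centre undrawn in both compounds, though compound 1 stands at a limit and not a number.

As far as these compounds go, the make-up of the undrawn sample of compound 4 stays open. So does whether a longer chain, or a carboxylic acid in place of the alcohol, would keep this activity and the preference for the R form.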